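A few compounds are considered here, and "the series" means these few. Any claim that something is new, unique, unknown or untested is made for them only; others in the source may bear on it.

Measured compounds:
- compound 1, `O=C(N/N=C/c1ccc(F)cc1)Nc1cc2c(Nc3ccc(F)c(Cl)c3)ncnc2cc1O[C@H]1CCOC1`: 35100 nM
- compound 2, `N#Cc1ccc(/C=N/NC(=O)Nc2cc3c(Nc4ccc(F)c(Cl)c4)ncnc3cc2O[C@H]2CCOC2)cc1`: 29100 nM
- compound 3, `COc1ccc(/C=N/NC(=O)Nc2cc3c(Nc4ccc(F)c(Cl)c4)ncnc3cc2O[C@H]2CCOC2)cc1`: 33100 nM

In a functional assay on A549 cells (Homo sapiens) for cytotoxicity, read by MTT assay, with a stated time of 72 h (a higher number here means a weaker inhibitor, a lower number a stronger inhibitor), compound 3 gives 33100 nM and stands second highest of the three numbers, though its nearest neighbour is compound 1 at a 1.1-fold lower number from compound 1 to compound 3 (0.03 log units; within the scatter) and compound 2 at a 1.1-fold higher number from compound 2 to compound 3 (0.06 log units; within the scatter), so all three compounds sit within the scatter of one another.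

Compound 4, `CCN(CC)c1ccc(/C=N/NC(=O)Nc2cc3c(Nc4ccc(F)c(Cl)c4)ncnc3cc2O[C@H]2CCOC2)c(O)c1`, has not yet been measured. It differs from compound 3 in one place: 4-(diethylamino)-2-hydroxyphenyl in place of 4-methoxyphenyl on a carbon with a double bond to nitrogen. The measured steps that bear on this are the swaps of the group on the same aromatic ring, a 1.2-fold lower number from compound 1 to compound 2 (0.08 log units; within the scatter) and a 1.1-fold lower number from compound 1 to compound 3 (0.03 log units; within the scatter); each stayed within the scatter. Among the compounds with values here, the change to compound 4 is larger than those, and no measured pair shows what it does, so no step beyond the scatter is expected in either direction.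

Compound 4 is therefore estimated at 30000 nM, with a range from 10000 nM to 90000 nM, a step of a 1.1-fold lower number from compound 3 to compound 4 (0.04 log units; within the scatter) expected.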

Compound 4, half-maximal inhibitory concentration: 15700 nM
Beside the measured number, compound 4's estimate is 1.9-fold (0.28 log units) above it; low and high end bracket the measured number.
By their numbers in this assay, from the lowest: compounds 4, 2, 3 and 1 (each within the scatter of the next, the first and the last beyond it).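

Within the data shown here, the earlier swaps of fluoro, cyano and methoxy on this aromatic ring all stayed within the scatter in this assay, so compound 4 gives the first sign that the group on this carbon with a double bond to nitrogen can matter. Among these compounds, the larger 4-(diethylamino)-2-hydroxyphenyl group brings a modest gain against two of the earlier compounds (a 2.1-fold lower number from compound 3 to compound 4 (0.32 log units; beyond the scatter); a 2.2-fold lower number from compound 1 to compound 4 (0.35 log units; beyond the scatter)), although the comparison with the cyano compound remains within the scatter (a 1.9-fold lower number from compound 2 to compound 4 (0.27 log units; within the scatter)). No measurement here explains the shift.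

The diethylamino and hydroxy groups enter together, so the compounds shown cannot assign the change to either one. Also open, as far as these compounds go, is how a 4-(diethylamino)phenyl group, a 2-hydroxyphenyl group or a ring bearing a carboxylic acid would behave here.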